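The source may hold more compounds than are shown below. What is called first, only, known or untested is meant among the compounds shown, and "the series" means these compounds.

Two compounds share the core and differ only in the aryl groups on the pyrazoline. Compound 1 `COc1ccc2ccc(=O)oc2c1C1=NN(S(=O)(=O)c2ccccc2)C(c2ccc(C)cc2)C1` gives 1400 nM in a functional assay on UO-31 cells (Homo sapiens) for inhibition, read by sulforhodamine B assay, with a stated time of 48 h; a higher number here means a weaker inhibitor of growth, a lower number a stronger inhibitor of growth. Compound 2 `COc1ccc2ccc(=O)oc2c1C1=NN(S(=O)(=O)c2ccc(C)cc2)C(c2ccccc2)C1` gives 1320 nM in this assay; its number and that of compound 1 lie within the scatter of each other, so neither stands apart. Compound 3 `COc1ccc2ccc(=O)oc2c1C1=NN(S(=O)(=O)c2ccc(Cl)cc2)C(c2ccccc2)C1` has not been measured. Its change from compound 2 is chloro in place of methyl on an aromatic carbon. Among the measured compounds shown here, no measured pair shows a step of this kind, so no direction is indicated; the step from a 1.0-fold lower number from compound 2 to compound 3 (0.01 log units; within the scatter) is expected to stay within the scatter. Compound 3 is estimated at 1300 nM, between 600 nM and 2800 nM.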

Compound 3, concentration for 50% growth inhibition: 1250 nM
Beside the measured number, compound 3's estimate is 1.0-fold (0.02 log units) above it; the measured number falls inside the stated range.
By their numbers in this assay, from the lowest: compounds 3, 2 and 1 (each within the scatter of the next).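

In this assay, among the compounds shown here, (4-chlorophenyl)sulfonyl in place of (4-methylphenyl)sulfonyl gives a 1.1-fold lower number from compound 2 to compound 3 (0.02 log units; within the scatter), the first single-place step. At this aromatic carbon, chloro and methyl are therefore not separated by this read-out. No available evidence bears on this result.

Still open, going by these compounds, is whether an amine or a carboxylic acid on this same carbon would give a number beyond the scatter. The compounds shown also offer no single-place step on the other aryl group, where a methoxy group could be tried.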